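Chloro to methyl on the acyl chain of compound 2

The compounds below may be only part of what the source reports. "The series", "measured", "known", "first", "only" and "open" are said of these compounds alone.

Compound 2 `CCCCC(OC)c1cccc(NC(=O)NC(=O)CCl)c1` is measured in a functional assay on HT-29 cells (Homo sapiens) for antiproliferative activity, with a stated time of 48 h (a higher number here means a weaker inhibitor, a lower number a stronger inhibitor), at 10000 nM. Compound 1 `CCCCC(O)c1cccc(NC(=O)NC(=O)CCl)c1` gives 10000 nM, and the step of no change at the digits printed from compound 1 to compound 2 (within the scatter). Compound 3 `CCCCC(OC)c1cccc(NC(=O)NC(=O)CC)c1` differs from compound 2 by methyl in place of chloro on a saturated chain carbon bound to a carbonyl carbon. For the measured compounds named here, no measured step touches the acyl chain; the only step in hand, from compound 1 to compound 2, changed an oxygen substituent on the side chain and bears little on this change. The expected step of a 1.5-fold higher number from compound 2 to compound 3 (0.18 log units; within the scatter) for compound 3 is therefore small. Compound 3 is estimated at 15000 nM, within 7000 nM to 40000 nM.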

Compound 3, half-maximal inhibitory concentration: > 100000 nM
Compound 3 ended at the assay's limit; the forecaster's own chance of this, stated with the estimate: 50%; middle value at least 6.6-fold (0.82 log units) from the limit.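

In this assay, the acyl chain responds where the oxygen substituent on the side chain did not: methyl in place of chloro on a saturated chain carbon bound to a carbonyl carbon gives an at least 10-fold higher number from compound 2 to compound 3 (1.00 log units; beyond the scatter). Compound 3 stands at a limit of the assay, not at a number: the limit of > 100000 nM in this assay, at which 1 of the 3 values shown sits. For this pair, the measurable activity goes with chloro at this place. The compounds shown leave open whether bromo or fluoro there would hold the value of compound 2, and whether the same change would act alike on the hydroxy side chain of compound 1.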